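The source may report more compounds than this note shows. Statements on the series, on what has been measured and on what is new or still open speak of the compounds shown alone.

Compound 1 `C[C@@H]1CN(c2sc(C(F)(F)F)nc2-c2nc3ccccc3[nH]2)CCN1C(=O)Cn1cnc2cccnc21`: 1.6 nM
Compound 2 `CCOc1ncc(-c2nc(C(F)(F)F)sc2N2CCN(C(=O)Cn3cnc4cccnc43)[C@H](C)C2)cn1`: 2 nM

Of the compounds shown here, two have been measured in a functional assay on CHO-K1 cells for antagonist activity at C-X-C chemokine receptor type 3 (Homo sapiens), read by FLIPR, with a stated time of 10 min; a lower number here means a stronger inhibitor, a higher number a weaker inhibitor. Compound 1 gives 1.6 nM, and compound 2 gives 2 nM. The step of a 1.3-fold higher number from compound 1 to compound 2 (0.10 log units; within the scatter) shows that the two stand within the scatter of each other; compound 2 has the higher of the two numbers, but its gap to compound 1 lies within the scatter, so no order can be read from it.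

Compound 3 `Cc1ncc(-c2nc(C(F)(F)F)sc2N2CCN(C(=O)Cn3cnc4cccnc43)[C@H](C)C2)cn1` differs from compound 2 by methyl in place of ethoxy on an aromatic carbon, on an aromatic carbon of a six-membered aromatic ring with two nitrogen, between two ring nitrogen atoms, para to a large group. Going by the values given here, no measured step bears directly on this change: the only measured step replaces a different group at a different place, and it fell within the scatter. Since compound 2 gives 2 nM and nothing measured points either way, a step of no more than the scatter is expected, a 1.5-fold higher number from compound 2 to compound 3 (0.18 log units; within the scatter), with a wider uncertainty than a measured step would allow. Compound 3 is therefore expected to give 3 nM, between 1 nM and 10 nM.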

Compound 3, half-maximal inhibitory concentration: 3.6 nM
Compound 3: middle estimate off by 1.2-fold (0.08 log units), on the low side; measured number inside the range.
By their numbers in this assay, from the lowest: compounds 1, 2 and 3 (each within the scatter of the next, the first and the last beyond it).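

At this carbon, between two ring nitrogen atoms and para to a large group, the ethoxy group gives way to methyl with a 1.8-fold higher number from compound 2 to compound 3 (0.26 log units; within the scatter) in this assay, so the step stays small even though the oxygen and two further heavy atoms leave. The ethoxy oxygen, the only hydrogen-bond acceptor in that group, is therefore not shown to be needed for activity in this series. Set against the benzimidazole, however, the 2-methylpyrimidin-5-yl group gives the first step to pass the scatter, a 2.3-fold higher number from compound 1 to compound 3 (0.35 log units; beyond the scatter) in this assay, though only a modest one.

On these data alone, whether an amine, a hydroxyl or a longer chain such as propoxy at this carbon would stay as close to compound 2 remains open. Nothing available explains either step.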